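Compound 3 loses the benzyl group of compound 2

A few compounds are considered here, and "the series" means these few. Any claim that something is new, unique, unknown or untested is made for them only; others in the source may bear on it.

In a functional assay on Caco-2 cells (Homo sapiens) for inhibition, read by MTT assay, with a stated time of 48 h, tested at 10 uM (on this read-out lower numbers stand for less inhibition of growth and higher numbers for more inhibition of growth at the one concentration tested), compound 2 `Cc1cc(=O)c2c(O)c(CN3CCC(Cc4ccccc4)CC3)c(O)c([C@H]3CCN(C)C[C@H]3O)c2o1` stands highest of the two measured compounds at 21%. Compound 1 `COc1ccc(COc2cc(O)c3c(=O)cc(C)oc3c2[C@H]2CCN(C)C[C@H]2O)cc1` gives 8% of growth inhibition. The gap between these two compounds lies beyond the scatter. Compound 3 `Cc1cc(=O)c2c(O)c(CN3CCCCC3)c(O)c([C@H]3CCN(C)C[C@H]3O)c2o1` differs from compound 2 by hydrogen in place of benzyl on a saturated ring carbon with hydrogen in place of benzyl on a saturated ring carbon. For the measured compounds named here, no measured pair shows what such a change does, so only a small fall in this assay is expected, none beyond the scatter. The estimated change is a number 8 percentage points lower from compound 2 to compound 3 (within the scatter) and stays modest in size. For compound 3 the expected value is 13% within an estimated range from 3% to 26% on this read-out.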

Compound 3, percent growth inhibition at one concentration: 22%
Compound 3: middle estimate off by 9 percentage points, on the low side, and the stated range covers the measured number.
By their numbers in this assay, from the lowest: compound 1; then compounds 2 and 3 (each within the scatter of the next).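

In this assay, putting hydrogen in place of benzyl on the saturated ring carbon gives a number 1 percentage points higher from compound 2 to compound 3 (within the scatter). For this pair, then, the benzyl group is not needed to keep growth inhibition at the one concentration tested, and this read-out does not separate benzyl from hydrogen at this position. Nothing given here explains this result. Going by these compounds, whether an amine, a carboxylic acid or a longer alkyl chain on the same ring carbon would read differently stays open, as does whether the same holds for a phenyl group placed there.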